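Amide aryl swap: expectation for compound 3

The source may report more compounds than this note shows. Statements on the series, on what has been measured and on what is new or still open speak of the compounds shown alone.

Of the compounds shown here, two carry numbers so far. In a functional assay on HOS cells (Homo sapiens) for inhibition, read by MTT assay, with a stated time of 72 h (on this read-out lower numbers stand for stronger inhibition and higher numbers for weaker inhibition), compound 1 `COc1ccccc1NC(=O)CCC(=O)OCCCCCCSc1ccc([N+](=O)[O-])c2nonc12` gives 2850 nM. In this assay compound 2 `O=C(CCC(=O)OCCCCCCSc1ccc([N+](=O)[O-])c2nonc12)Nc1ccc(F)cc1` gives 2080 nM. The only measured step, a 1.4-fold lower number from compound 1 to compound 2 (0.14 log units; within the scatter), was within the scatter, so on the numbers shown compound 2 and compound 1 cannot be told apart, and compound 2 stands at one end of a pair that differs only by noise.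

Compound 3 `COc1ccc(NC(=O)CCC(=O)OCCCCCCSc2ccc([N+](=O)[O-])c3nonc23)cc1OC` is not yet measured. It differs from compound 2 by 3,4-dimethoxyphenyl in place of 4-fluorophenyl on an amide-type nitrogen. Among the compounds with values here, the one step that bears on it is the earlier change of the aryl group on the same amide-type nitrogen, a 1.4-fold lower number from compound 1 to compound 2 (0.14 log units; within the scatter), which did not move the number beyond the scatter. Within the data shown here, with only that step to go on, no step beyond the scatter is expected from compound 2 to compound 3, in either direction, and the wide range reflects that a single step is thin support. The expected step is a 1.2-fold higher number from compound 2 to compound 3 (0.08 log units; within the scatter). Compound 3 is therefore estimated at 2500 nM in this assay, with a range from 900 nM to 7000 nM.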

Compound 3, half-maximal inhibitory concentration: 1390 nM
For compound 3 the middle estimate is 1.8-fold (0.25 log units) above the measured one, within the range that was stated.
By their numbers in this assay, from the lowest: compounds 3, 2 and 1 (each within the scatter of the next, the first and the last beyond it).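

At this position on the amide-type nitrogen, swapping the aryl group can now produce a step beyond the scatter: in this assay, 3,4-dimethoxyphenyl in place of the aryl group of compound 1 gives a 2.1-fold lower number from compound 1 to compound 3 (0.31 log units; beyond the scatter), though the step is modest. Against 4-fluorophenyl, the same group gives a 1.5-fold lower number from compound 2 to compound 3 (0.18 log units; within the scatter), so compound 2 and compound 3 cannot be told apart, and only the two ends of the set of three separate, with compound 2 within the scatter of both. No measurement is available that explains the separation of compound 1 and compound 3.

All three aryl groups shown are substituted phenyl rings carrying fluorine or methoxy groups, and together they span little more than the scatter, so how far this position can move the number remains open. Also open, on these data alone, is whether an amine or a carboxylic acid on the aryl group, or a longer chain in the linker to the shared core, would give a larger step in this assay.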